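The source may hold more compounds than are shown below. What is called first, only, known or untested is meant among the compounds shown, and "the series" means these compounds.

Compounds measured in this assay so far:
compound 1 `Cc1cc2c(cc1C(=O)c1ccc(C(=O)OCCCCOC(=O)c3ccc(C(=O)Nc4ccc5c(c4)C(C)(C)CCC5(C)C)cc3)cc1)C(C)(C)CCC2(C)C` — 84100 nM
compound 2 `CCCC(CCC)C(=O)OCCCCOC(=O)c1ccc(C(=O)Nc2ccc3c(c2)C(C)(C)CCC3(C)C)cc1` — > 1000000 nM

In a functional assay on K562 cells (Homo sapiens) for inhibition, read by MTT assay, with a stated time of 48 h (on this read-out higher numbers stand for weaker inhibition and lower numbers for stronger inhibition), compound 1 gives 84100 nM. Compound 2 gives no number here, only a limit, > 1000000 nM. That value sits at the limit of > 1000000 nM in this assay, at which 1 of the 2 values shown sits. Compound 3 `CCCC(CCC)C(=O)OCCCOC(=O)c1ccc(C(=O)Nc2ccc3c(c2)C(C)(C)CCC3(C)C)cc1` differs from compound 2 by ((1-propylbutyl)carbonyl)oxy in place of (((1-propylbutyl)carbonyl)oxy)methyl on a saturated chain carbon, three bonds along the chain from an oxygen next to a carbonyl group. Among the compounds with values here, no measured pair brackets this change, and compound 2 itself stands at a limit, so the expectation for compound 3 is no shift beyond the scatter. Compound 3 is estimated at 1000000 nM (range 300000 nM to 3000000 nM), most likely again reported only as a limit. The expected step from compound 2 to compound 3 is a number no higher from compound 2 to compound 3 (the limit leaves the size open).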

Compound 3, half-maximal inhibitory concentration: > 1000000 nM
Compound 3: no number, only a limit; the forecaster's own chance of this, stated with the estimate: 70%; the middle value sits exactly at the limit.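

No step can be read between compound 2 and compound 3, which both give only a limit, not a number, in this assay. The compounds shown leave open what (((1-propylbutyl)carbonyl)oxy)methyl to ((1-propylbutyl)carbonyl)oxy does to inhibition.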